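The compounds below may be only part of what the source reports. "The series", "measured", "known", "first", "only" and "open" are said of these compounds alone.

Compound 1 `O=C[C@H](C[C@@H]1CCNC1=O)NC(=O)[C@H](CC1CC1)NC(=O)OCc1cccc(F)c1` opens the series. In an ADME assay on Vero C1008 cells (Chlorocebus sabaeus) for cytotoxicity, read by luminescence and CellTiter-Glo, with a stated time of 24 h (on this read-out lower numbers stand for higher toxicity in this test and higher numbers for lower toxicity in this test), compound 1 gives only a limit of the assay, > 200000 nM. Compound 2 `O=C[C@H](C[C@@H]1CCNC1=O)NC(=O)[C@H](CC1CC1)NC(=O)OCCc1cccc(Cl)c1` likewise gives only a limit in this assay, > 200000 nM. The step that the two limits leave unreadable from compound 1 to compound 2 therefore cannot be read, since both values sit at the limit of > 200000 nM in this assay, at which 2 of the 2 values shown sit. Compound 3 `C[C@H](OC(=O)N[C@@H](CC1CC1)C(=O)N[C@H](C=O)C[C@@H]1CCNC1=O)c1ccccc1` differs from compound 2 by 1-phenylethyl in place of 2-(3-chlorophenyl)ethyl on an oxygen next to a carbonyl group. Among the measured compounds shown here, no measured step bears on this change, and with both neighbours at the limit no step beyond the scatter is expected. Compound 3 is therefore estimated at 200000 nM, between 100000 nM and 400000 nM, an expected step of a number no higher from compound 2 to compound 3 (the limit leaves the size open).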

Compound 3, half-maximal cytotoxic concentration: > 200000 nM
Compound 3 was reported as a limit (the forecaster's own chance of this, stated with the estimate: 80%); the middle value lies on the limit itself.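

Compound 3 gives only a limit, so neither step to it, from compound 1 or from compound 2, can be read: the limit of > 200000 nM in this assay, at which 3 of the 3 values shown sit. The compounds shown leave open whether any of these changes shifts the half-maximal cytotoxic concentration at all.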